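Piperidin-1-yl in place of dipropylamino in compound 4

The compounds below may be only part of what the source reports. "The series", "measured", "known", "first", "only" and "open" are said of these compounds alone.

In a functional assay on K562 cells (Homo sapiens) for cytotoxicity, read by MTT assay, with a stated time of 72 h (a higher number here means a weaker inhibitor, a lower number a stronger inhibitor), compound 1 `CC(C)NC(=S)N/N=C1\CC(c2ccc(O)cc2)Oc2cc(O)ccc21` gives 21300 nM and compound 2 `CCCCNC(=S)N/N=C1\CC(c2ccc(O)cc2)Oc2cc(O)ccc21` gives 17000 nM while compound 3 `CCCN(CCC)C(=S)N/N=C1\CC(c2ccc(O)cc2)Oc2cc(O)ccc21` gives 12400 nM on the same scale. Compound 3 does not stand apart from the other two: both a 1.7-fold lower number from compound 1 to compound 3 (0.23 log units; within the scatter) and a 1.4-fold lower number from compound 2 to compound 3 (0.14 log units; within the scatter) stay within the scatter of repeat measurements, and so does a 1.3-fold lower number from compound 1 to compound 2 (0.10 log units; within the scatter) in the swap of isopropyl for butyl.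

Compound 4 `Oc1ccc(C2C/C(=N\NC(=S)N3CCCCC3)c3ccc(O)cc3O2)cc1` carries piperidin-1-yl in place of dipropylamino on a thiocarbonyl carbon. The closest evidence is the pair of steps ending at compound 3, since they change the group at this same place. Neither goes beyond the scatter. For the measured compounds named here, no measured compound has a ring at this place, however, so the evidence is indirect and the range has to stay wide.

Starting from compound 3 at 12400 nM and seeing only small steps so far, no step beyond the scatter is expected in this assay here. The expected step is a 1.0-fold higher number from compound 3 to compound 4 (0.02 log units; within the scatter) on this estimate. For compound 4 the estimated value is 13000 nM with an expected range from 6000 nM to 28000 nM in this measurement.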

Compound 4, half-maximal inhibitory concentration: 13700 nM
Compound 4: middle estimate off by 1.1-fold (0.02 log units), on the low side; low and high end bracket the measured number.
By their numbers in this assay, from the lowest: compounds 3, 4, 2 and 1 (each within the scatter of the next).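

In this assay, the first ring at this place, on a thiocarbonyl carbon, cannot be told apart from the open dipropylamino group: a 1.1-fold higher number from compound 3 to compound 4 (0.04 log units; within the scatter) shows that tying the chains into piperidin-1-yl leaves the reading within the scatter. The ring also stays within the scatter of the two groups that keep a hydrogen on the nitrogen, with a 1.2-fold lower number from compound 2 to compound 4 (0.09 log units; within the scatter) and a 1.6-fold lower number from compound 1 to compound 4 (0.19 log units; within the scatter), so these four compounds show that this place accepts a six-membered ring as well as the branched and straight chains, with no measurable gain or loss. No measurement here offers an explanation for why the ring and the chains read alike.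

Still open, going by these compounds, is whether a ring with a second hetero atom, such as morpholin-4-yl or piperazin-1-yl, or an aromatic group such as phenylamino, would move the number beyond the scatter at this place. On these data alone, the shared core is also the same in all four compounds, so the effect of a change there, such as a methoxy group in place of a hydroxyl group, remains unknown.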